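Ring in place of chain on the carbonyl of compound 3

The compounds below may be only part of what the source reports. "The series", "measured", "known", "first", "only" and "open" are said of these compounds alone.

Compound 3 `CCCC(=O)N1CCC(c2cc(OC)ccc2N)=N1` is measured in an assay on isolated protein for inhibition of Nitric oxide synthase, inducible (Homo sapiens), with a stated time of 30 min, tested at 1 mM (on this read-out lower numbers stand for less inhibition and higher numbers for more inhibition at the one concentration tested (going by the name of the read-out)), where compound 3 gives 13.1%. Of the three measured compounds, compound 3 stands second highest: compound 2 `Nc1ccc(Cl)cc1C1=NN(C(=O)C2CC2)CC1` gives 18.9%, within the scatter of compound 3, and compound 1 `CCCC(=O)N1CCC(c2cc(Cl)ccc2N)=N1` gives 0.29%, beyond the scatter below it. Compound 4 `COc1ccc(N)c(C2=NN(C(=O)C3CCCC3)CC2)c1` differs from compound 3 by cyclopentyl in place of propyl on a carbonyl carbon. Among the measured compounds shown here, one measured step bears on this: a number 18.6 percentage points higher from compound 1 to compound 2 (beyond the scatter), a ring in place of the same chain on the same carbonyl carbon. Compound 4 is therefore expected to move upward from compound 3 by a modest step, a number 14.9 percentage points higher from compound 3 to compound 4 (beyond the scatter). The estimate for compound 4 is 28%, with a range from 8% to 50%.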

Compound 4, a percentage reported as inhibition, at one concentration (the size of the read-out at that concentration, not a potency): 1.85%
For compound 4 the middle estimate is 26.2 percentage points above the measured one; measured number outside the range, below it.
By their numbers in this assay, from the lowest: compounds 1 and 4 (each within the scatter of the next); then compounds 3 and 2 (each within the scatter of the next).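

In this assay, the change of propyl to cyclopentyl on this carbonyl carbon gives a number 11.3 percentage points lower from compound 3 to compound 4 (beyond the scatter), whereas the earlier ring change gave a number 18.6 percentage points higher from compound 1 to compound 2 (beyond the scatter). A ring in place of propyl at this position therefore does not shift the read-out in one fixed direction across these compounds. Nothing available offers an explanation for the opposite signs. The compounds shown leave open whether ring size or the methoxy and chloro groups separate the two steps, since the two steps differ in both. On these data alone, how a cyclohexyl ring or a longer chain such as pentyl would read on this carbonyl also remains open.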